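Indazole for Indole on the Pyrazolopyrimidine Series

This account rests on a few compounds, and the source may have more. Where it says the series, first, only, none or still open, it means among the compounds named here.

In a functional assay on MCF7 cells (Homo sapiens) for inhibition, read by CCK-8 assay, with a stated time of 48 h (on this read-out higher numbers stand for weaker inhibition and lower numbers for stronger inhibition), compound 2 `COc1cc(-c2ccnc3cc(-c4ccc5cc[nH]c5c4)nn23)cc(OC)c1OC` gives 23 nM, the lowest number among the measured compounds. Compound 1 `Cn1ccc2cc(-c3cc4nccc(-c5ccc(F)cc5)n4n3)ccc21` gives 4580 nM in this assay, a gap beyond the scatter. For compound 3 `COc1cc(-c2ccnc3c(-c4ccc(C)cc4)cnn23)cc(OC)c1OC` this assay reports only a limit of > 10000 nM, not a number. Compound 4 `COc1cc(-c2ccnc3cc(-c4ccc5cnn(C)c5c4)nn23)cc(OC)c1OC` is not yet measured; it differs from compound 2 by 1-methyl-1H-indazol-6-yl in place of 1H-indol-6-yl on an aromatic carbon. Among the measured compounds shown here, no step between measured compounds isolates this change, so the expectation rests on compound 2 alone. Compound 4 is expected to stay near compound 2, with a modest shift toward a higher number that may not exceed the scatter, a 2.6-fold higher number from compound 2 to compound 4 (0.42 log units; beyond the scatter). Compound 4 is therefore estimated at 60 nM, within a range of 15 nM to 400 nM.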

Compound 4, half-maximal inhibitory concentration: 279 nM
For compound 4 the middle estimate is 4.7-fold (0.67 log units) below the measured one, and the stated range covers the measured number.
By their numbers in this assay, from the lowest: compound 2; then compound 4; then compound 1. At a limit, above all of these: compound 3.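

In this assay this aromatic carbon proves sensitive to the group it carries: 1-methyl-1H-indazol-6-yl in place of 1H-indol-6-yl gives a 12-fold higher number from compound 2 to compound 4 (1.08 log units; beyond the scatter) and so the two groups are not interchangeable here. The change removes the hydrogen-bond donor and brings in a second ring nitrogen and a methyl together, so this single step cannot assign the rise to any one of them.

As far as these compounds go, whether 1H-indazol-6-yl without the methyl, or an amine at this place, would hold the lower number remains open. Nothing measured here bears on the cause of the step.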